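Working notes: 1H-indol-4-yl to 1-benzofuran-5-yl

The source may hold more compounds than are shown below. What is called first, only, known or untested is meant among the compounds shown, and "the series" means these compounds.

Measured in a functional assay on K562 cells (Homo sapiens) for inhibition, read by trypan blue exclusion, with a stated time of 72 h; a lower number here means a stronger inhibitor, a higher number a weaker inhibitor:
- compound 1 `Cn1c(=O)c(S(=O)(=O)c2ccc(F)cc2)cc2cnc(Nc3ccc4occc4c3)nc21`: 5000 nM
- compound 2 `Cn1c(=O)c(S(=O)(=O)c2ccc(F)cc2F)cc2cnc(Nc3cccc4[nH]ccc34)nc21`: 1500 nM

Compound 2 holds the lower of the two numbers, and compound 1 lies beyond the scatter from it. Compound 3 `Cn1c(=O)c(S(=O)(=O)c2ccc(F)cc2F)cc2cnc(Nc3ccc4occc4c3)nc21` is the next compound to follow from compound 2: 1-benzofuran-5-yl in place of 1H-indol-4-yl on a nitrogen on an aromatic ring. Among the measured compounds shown here, no measured pair isolates this change. Compound 1 also carries 1-benzofuran-5-yl and reads 5000 nM, so a moderate move to a higher number in this assay is expected. The expected change is a 2.3-fold higher number from compound 2 to compound 3 (0.37 log units; beyond the scatter). Compound 3 is estimated at 3500 nM, with an expected range of 1200 nM to 10000 nM.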

Compound 3, half-maximal inhibitory concentration: 15000 nM
Compound 3: the middle estimate sits 4.3-fold (0.63 log units) below what was measured; the measured number lies above the stated range.
By their numbers in this assay, from the lowest: compound 2; then compound 1; then compound 3.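

In this assay, 1-benzofuran-5-yl in place of 1H-indol-4-yl on the nitrogen gives a 10-fold higher number from compound 2 to compound 3 (1.00 log units; beyond the scatter) and is now isolated as a single change, one that loses the hydrogen-bond donor counted for 1H-indol-4-yl. With 1-benzofuran-5-yl held constant, fluoro in place of hydrogen on an aromatic carbon gives a 3.0-fold higher number from compound 1 to compound 3 (0.48 log units; beyond the scatter) in the same direction as the first step. No evidence on hand bears on the origin of either step.

On these data alone, whether the fluoro step carries over to compounds with 1H-indol-4-yl remains open. So does the effect of an amine or hydroxyl group on the ring system attached to that nitrogen.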